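A few compounds are considered here, and "the series" means these few. Any claim that something is new, unique, unknown or untested is made for them only; others in the source may bear on it.

Compound 1, `C/C(=N\NC(=O)COc1cccc2ccccc12)c1ccc(C#N)cc1Br`: 12.1 ug/mL
Compound 2, `Cc1ccc(/C=N/NC(=O)COc2cccc3ccccc23)cc1`: 83.9 ug/mL

Both were read in an ADME assay on MT4 cells (Homo sapiens) for cytotoxicity, read by MTT assay, with a stated time of 4 days; on this read-out higher numbers stand for lower toxicity in this test and lower numbers for higher toxicity in this test. Compound 2 has the higher of the two numbers, and the gap down to compound 1 lies beyond the scatter. Compound 3, `O=C(COc1cccc2ccccc12)N/N=C/c1ccc(Br)cc1`, has not yet been measured. It differs from compound 2 in one place: bromo in place of methyl on an aromatic carbon. For the measured compounds named here, no measured pair shows this change, so its effect has to be estimated. With nothing in the data pointing to a large shift, a step within the scatter, in no particular direction, is expected: a 1.4-fold lower number from compound 2 to compound 3 (0.15 log units; within the scatter). Compound 3 is accordingly estimated at 60 ug/mL, somewhere between 25 ug/mL and 130 ug/mL.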

Compound 3, half-maximal cytotoxic concentration: 106 ug/mL
Beside the measured number, compound 3's estimate is 1.8-fold (0.25 log units) below it; the range from low to high includes it.
By their numbers in this assay, from the lowest: compound 1; then compounds 2 and 3 (each within the scatter of the next).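

In this assay, the first pair differing in one place gives a 1.3-fold higher number from compound 2 to compound 3 (0.10 log units; within the scatter). On the ring position held by these groups, methyl and bromo therefore cannot be told apart in this test, and the large gap seen earlier with compound 1 does not arise from this change alone. No measurement available here offers an explanation for this result. An amine or a carboxylic acid at this position could behave quite differently. A single pair also cannot show whether the same holds on other cores.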